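Swapping methyl for hydroxy on the anilide ring

The compounds below may be only part of what the source reports. "The series", "measured", "known", "first", "only" and "open" are said of these compounds alone.

Compound 3 `Cc1ccc(NC(=O)C2(C(=O)Nc3ccc(Nc4ncc5cc(C(=O)N(C)C)n(C6CCCC6)c5n4)cc3)CC2)cc1` gives 40.2% in a functional assay on A549 cells (Homo sapiens) for inhibition, read by CCK-8 assay, with a stated time of 72 h, tested at 1 uM (a higher number here means more inhibition of growth at the concentration tested, a lower number less inhibition of growth), the second highest of the three numbers shown: compound 1 `CN(C)C(=O)c1cc2cnc(Nc3ccc(NC(=O)C4(C(=O)Nc5ccccc5F)CC4)cc3)nc2n1C1CCCC1` gives 79.1%, while compound 2 `CN(C)C(=O)c1cc2cnc(Nc3ccc(NC(=O)C4(C(=O)Nc5ccc(Cl)c(C(F)(F)F)c5)CC4)cc3)nc2n1C1CCCC1` gives 1.1%. Compound 4 `CN(C)C(=O)c1cc2cnc(Nc3ccc(NC(=O)C4(C(=O)Nc5ccc(O)cc5)CC4)cc3)nc2n1C1CCCC1` differs from compound 3 by hydroxy in place of methyl on an aromatic carbon. Within the data shown here, the only measured steps touching this ring are a number 38.9 percentage points lower from compound 1 to compound 3 (beyond the scatter) and a number 39.1 percentage points higher from compound 2 to compound 3 (beyond the scatter); both are large, and neither involves a hydroxy group, so they show only that this ring can move this assay widely. A moderate step in either direction, beyond the scatter, is therefore considered possible but not predictable in sign. Compound 4 is estimated at 45%, between 10% and 80%, which is expected to mean a number 4.8 percentage points higher from compound 3 to compound 4 (within the scatter).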

Compound 4, percent growth inhibition at one concentration: 93.6%
Estimate against measurement, compound 4: 48.6 percentage points below; the measured number lies above the stated range.
By their numbers in this assay, from the lowest: compound 2; then compound 3; then compound 1; then compound 4.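

In this assay, hydroxy in place of methyl on an aromatic carbon gives a number 53.4 percentage points higher from compound 3 to compound 4 (beyond the scatter), which shows that exchanging one heavy atom at this place is enough for a large change. The same 4-hydroxyphenyl group puts compound 4 highest of the four, with a number 14.5 percentage points higher from compound 1 to compound 4 (beyond the scatter), a modest step, and a number 92.5 percentage points higher from compound 2 to compound 4 (beyond the scatter). No measurement at hand accounts for this gain. The compounds shown leave open whether an amine or a methoxy group on this carbon would reach a similar level, and whether hydroxy would hold it on another carbon of the ring.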